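Adding a Methyl to the Pyrrolidine Ring of Compound 2

A few compounds are considered here, and "the series" means these few. Any claim that something is new, unique, unknown or untested is made for them only; others in the source may bear on it.

For the measured compounds named here, compound 2 `O=C(c1ccc(N2CCCC2)cc1Cl)N1CCCCc2ccccc21` is one of two compounds measured in an assay on HeLa cells for binding affinity to Vasopressin V2 receptor (Homo sapiens); a higher number here means a weaker inhibitor, a lower number a stronger inhibitor. Compound 2 gives 9 nM, the lowest of the two numbers. Its nearest neighbour is compound 1 `CNc1ccc(C(=O)N2CCCCc3ccccc32)c(Cl)c1`, which in this assay gives 35 nM. Going by the values given here, the one step between them, a 3.9-fold lower number from compound 1 to compound 2 (0.59 log units; beyond the scatter), came with pyrrolidin-1-yl in place of methylamino on an aromatic carbon. Compound 3 `CC1CCN(c2ccc(C(=O)N3CCCCc4ccccc43)c(Cl)c2)C1` differs from compound 2 by methyl in place of hydrogen on a saturated ring carbon: a methyl in place of hydrogen on a saturated ring carbon, two ring bonds from the ring nitrogen. Among the compounds with values here, no measured step touches this ring; the only known step concerns a different part of the shared core and was modest. Such a change is expected to leave the number close to where compound 2 stands. For compound 3 the estimate in this assay is 8 nM, within 3 nM to 25 nM. The step this estimate implies is expected to be a 1.1-fold lower number from compound 2 to compound 3 (0.05 log units; within the scatter).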

Compound 3, half-maximal inhibitory concentration: 51 nM
Compound 3: the middle estimate sits 6.4-fold (0.80 log units) below what was measured, and the stated range ends below it.
By their numbers in this assay, from the lowest: compound 2; then compounds 1 and 3 (each within the scatter of the next).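

In this assay, the pyrrolidine ring of compound 2 turns out to be sensitive to one added carbon: a methyl on a saturated ring carbon, two ring bonds from the ring nitrogen, gives a 5.7-fold higher number from compound 2 to compound 3 (0.75 log units; beyond the scatter). This is the first step shown at this ring, and it is about as large as the earlier gain from exchanging methylamino for pyrrolidin-1-yl. With 3-methylpyrrolidin-1-yl in place of methylamino, that gain is no longer visible, as a 1.5-fold higher number from compound 1 to compound 3 (0.16 log units; within the scatter) shows, and no measurement shown here accounts for the change.

The compounds shown leave open whether this loss belongs to methyl in particular or would also follow from a fluorine, a hydroxyl or an ethyl group on the same ring carbon. A single compound also cannot show how a methyl on any other carbon of this ring would behave.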